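A few compounds are considered here, and "the series" means these few. Any claim that something is new, unique, unknown or untested is made for them only; others in the source may bear on it.

Measured in an ADME assay on Jurkat cells (Homo sapiens) for cytotoxicity, read by MTT assay, with a stated time of 72 h; a higher number here means a weaker inhibitor, a lower number a stronger inhibitor:
compound 1 `O=C(O)c1cnc(Oc2ccc3c(c2)B(O)OC3)cn1`: > 100000 nM (a limit)
compound 2 `NC(=O)c1cnc(Oc2ccc3c(c2)B(O)OC3)cn1`: 48200 nM
compound 3 `CC(C)OC(=O)c1cnc(Oc2ccc3c(c2)B(O)OC3)cn1`: > 100000 nM (a limit)

Compound 3 gives no number in this assay, only a limit of the assay, > 100000 nM. Among the three compounds, only compound 2 has a measured number, 48200 nM.

Compound 4 `O=C(OC1CCCCC1)c1cnc(Oc2ccc3c(c2)B(O)OC3)cn1` keeps the core of compound 3 and carries cyclohexyl in place of isopropyl on an oxygen next to a carbonyl group.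

The nearest measured change, made on that same oxygen, is a step that the two limits leave unreadable from compound 1 to compound 3. Two other steps can be read, an at least 2.0-fold lower number from compound 1 to compound 2 (0.31 log units; beyond the scatter) and an at least 2.0-fold higher number from compound 2 to compound 3 (0.31 log units; beyond the scatter). Both turn on the amino group, however, and neither swaps one carbon group on the oxygen for another. The data therefore offer no direct measure of this change, and no clear step is expected in this assay. If a number does appear, a modest move to a lower number is the more likely outcome, and the estimate reads an at least 1.2-fold lower number from compound 3 to compound 4 (0.09 log units; that floor lies within the scatter). Compound 4 is expected to stay close to the limit that holds compound 3, because of the limit of > 100000 nM in this assay, at which 2 of the 3 values shown sit. The estimated value for compound 4 is 80000 nM, with an expected range from 30000 nM to 150000 nM.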

Compound 4, half-maximal inhibitory concentration: 52400 nM
Compound 4: the middle estimate sits 1.5-fold (0.18 log units) above what was measured, within the range that was stated.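

In this assay, going by these compounds alone, compound 4 is the first compound with a carbon group on the oxygen next to a carbonyl group to give a number rather than a limit, and the cyclohexyl there gives an at least 1.9-fold lower number from compound 3 to compound 4 (0.28 log units; that floor lies within the scatter) and an at least 1.9-fold lower number from compound 1 to compound 4 (0.28 log units; that floor lies within the scatter). Neither step can be sized further, and each remains only a floor, because compound 1 and compound 3 both stand at a limit of the assay: the limit of > 100000 nM in this assay, at which 2 of the 4 values shown sit. With cyclohexyloxy in place of amino on a carbonyl carbon, the comparison gives a 1.1-fold higher number from compound 2 to compound 4 (0.04 log units; within the scatter), so these two compounds cannot be told apart here, although one carries a carbon group on that oxygen and the other carries amino on the carbonyl carbon.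

With only isopropyl and cyclohexyl shown as carbon groups on this oxygen, and only cyclohexyl giving a number, the compounds cannot show whether the read-out follows the size of the group or the presence of the ring. From the compounds shown here alone, a phenyl group or an open n-hexyl chain on the same oxygen, or a methylamino group in place of amino on the carbonyl carbon, would bear on that question, and what each would give remains open.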